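Aryl substituent series on the shared core: amino to dimethylamino

This account rests on a few compounds, and the source may have more. Where it says the series, first, only, none or still open, it means among the compounds named here.

Measured compounds:
compound 1, `O=[N+]([O-])c1cccc(C2=NC(c3ccc(F)cc3)(c3ccc(F)cc3)CN2)c1`, 4.3 nM
compound 2, `CC(=O)c1cccc(C2=NC(c3ccc(F)cc3)(c3ccc(F)cc3)CN2)c1`, 44 nM
compound 3, `Nc1cccc(C2=NC(c3ccc(F)cc3)(c3ccc(F)cc3)CN2)c1`, 300 nM

The three measured compounds share one core and differ only in the group on the aromatic carbon. In an assay on LM cells for displacement of a labelled ligand from Neuropeptide Y receptor type 5 (Homo sapiens) (a lower number here means a stronger inhibitor, a higher number a weaker inhibitor), compound 1 gives 4.3 nM, the lowest number of the three. Compound 3 stands at the top: its number is higher than that of compound 2 by a 6.8-fold higher number from compound 2 to compound 3 (0.83 log units; beyond the scatter) and higher than that of compound 1 by a 70-fold higher number from compound 1 to compound 3 (1.84 log units; beyond the scatter), both steps beyond the scatter. The step of a 10-fold higher number from compound 1 to compound 2 (1.01 log units; beyond the scatter) shows that acetyl in place of nitro also raises the number.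

Compound 4, `CN(C)c1cccc(C2=NC(c3ccc(F)cc3)(c3ccc(F)cc3)CN2)c1`, is not yet measured. It differs from compound 3 by dimethylamino in place of amino on an aromatic carbon. Going by the values given here, no measured step is of the same kind: the steps seen replace nitro by acetyl or amino, or acetyl by amino, and all are large or modest moves away from compound 1. None of them tells how adding two methyl groups to the amino nitrogen will read. The expectation for compound 4 in this assay is therefore a step of a 1.5-fold lower number from compound 3 to compound 4 (0.18 log units; within the scatter), small and not clearly beyond the scatter in either direction. Compound 4 is estimated at 200 nM, with a range from 60 nM to 700 nM.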

Compound 4, half-maximal inhibitory concentration: > 1000 nM
Compound 4 ended at the assay's limit; the forecaster's own chance of this, stated with the estimate: 5%; middle value at least 5.0-fold (0.69 log units) from the limit.
By their numbers in this assay, from the lowest: compound 1; then compound 2; then compound 3. At a limit, above all of these: compound 4.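

Adding the two methyl groups to the amino nitrogen is not a neutral change at this position on the aromatic ring: in this assay the step is an at least 3.3-fold higher number from compound 3 to compound 4 (0.52 log units; beyond the scatter), so dimethylamino moves the number further from that of the nitro group than amino does. The wider comparisons confirm this, with an at least 22-fold higher number from compound 2 to compound 4 (1.35 log units; beyond the scatter) and an at least 230-fold higher number from compound 1 to compound 4 (2.36 log units; beyond the scatter), and they place dimethylamino at the high end of the four groups, a place that nitro, acetyl and amino alone could not reveal. The result for compound 4 is a limit of the assay and not a number, so these steps give only the least size of each change: the limit of > 1000 nM in this assay, at which 1 of the 4 values shown sits.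

The true size of the dimethylamino step therefore remains unknown, and the compounds shown cannot separate the added carbons from the loss of the hydrogen-bond donor on the nitrogen. A methylamino group, with one methyl on the nitrogen, or an acetamido group would help to tell whether the rise in the number begins with a single substituent on that nitrogen.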